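The source may hold more compounds than are shown below. What is called first, only, known or untested is meant among the compounds shown, and "the series" means these compounds.

Measured so far in an in vitro assay on COS-1 cells for inhibition of sodium-dependent dopamine transporter (Homo sapiens); a higher number here means a weaker inhibitor, a lower number a stronger inhibitor:
compound 1, `COC(=O)C1=C(c2ccc(Cl)c(Cl)c2)C2CCC1C2`, 6760 nM;
compound 2, `COC(=O)C1=C(c2cccc(Cl)c2)C2CCC1C2`, 105000 nM;
compound 3, `COC(=O)C1=C(c2ccccc2Cl)C2CCC1C2`, 372000 nM.

Compound 3 gives the highest of the three numbers in this assay; the difference between the core of compound 3 and that of compound 2 is not broken down here. Between compound 2 and compound 1 the change is chloro in place of hydrogen on an aromatic carbon, and the step was a 16-fold lower number from compound 2 to compound 1 (1.19 log units; beyond the scatter).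

Compound 4, `COC(=O)C1=C(c2ccc(Cl)cc2Cl)C2CCC1C2`, is not yet measured. Its change from compound 3 is chloro in place of hydrogen on an aromatic carbon. This is the same kind of change as that from compound 2 to compound 1, but the surroundings differ: in compound 1 the entering chloro is ortho to a chloro group, in compound 4 it is meta to a chloro group; in both it is para to a large group.

Among the measured compounds shown here, only one measured step of this kind exists, so the expectation rests on it alone. Starting from compound 3 at 372000 nM, a step of similar size is expected, a 17-fold lower number from compound 3 to compound 4 (1.23 log units; beyond the scatter), because the single precedent is a 16-fold lower number from compound 2 to compound 1 (1.19 log units; beyond the scatter). Compound 4 is thus estimated at 22000 nM, between 6000 nM and 80000 nM.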

Compound 4, inhibition constant: 22900 nM
For compound 4 the middle estimate is 1.0-fold (0.02 log units) below the measured one; the range from low to high includes it.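

In this assay, chloro in place of hydrogen on an aromatic carbon gives a 16-fold lower number from compound 3 to compound 4 (1.21 log units; beyond the scatter), and this step matches the one already seen on the other core: the same change on two cores in this assay, a 16-fold lower number (1.19 log units; beyond the scatter) from compound 2 to compound 1 and a 16-fold lower number (1.21 log units; beyond the scatter) from compound 3 to compound 4, 1.0-fold (0.02 log units) apart, within the scatter of two such steps. Among the compounds shown here, the size of the step therefore carries over between these two cores, even though the entering chloro in compound 4, meta to a chloro group, has different surroundings from the one in compound 1. For the compounds shown here, this rests on only two steps, both with the same entering group, so it does not show that the step would keep its size on a further core or at another place on the ring, and it gives no explanation for the size.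

All the compounds shown carry only chloro on the aromatic ring, so it remains open whether fluoro, a methoxy group or an amine entering at the same place would give a step of similar size. Also open, as far as these compounds go, is how the step would behave if a carboxylic acid or an amide took the place of the methyl ester.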